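The compounds below may be only part of what the source reports. "The series", "measured", "known", "first", "only" and "open" are said of these compounds alone.

Compound 1, `CCOc1ccccc1Nc1nc(SCc2ccc(C(F)(F)F)cc2)nc2ccccc12`, gives in a functional assay on MGC-803 cells (Homo sapiens) for cytotoxicity, read by MTT assay, with a stated time of 72 h (a higher number here means a weaker inhibitor, a lower number a stronger inhibitor), a value of > 50000 nM, which is a limit of the assay rather than a number.
Compound 2, `FC(F)(F)c1ccc(CSc2nc(Nc3ccc(C(F)(F)F)cc3)c3ccccc3n2)cc1`, gives 6170 nM in this assay.
Compound 3, `CCOc1ccc(Nc2nc(SCc3ccc(C(F)(F)F)cc3)nc3ccccc23)cc1`, gives 37000 nM in this assay.

Of the two numbers obtained, compound 3 has the higher one; its nearest neighbour is compound 2, and the step of a 6.0-fold higher number from compound 2 to compound 3 (0.78 log units; beyond the scatter) lies beyond the scatter. Compound 1 gives only a limit, so its distance from compound 3 can be sized only as the floor of an at least 1.3-fold lower number from compound 1 to compound 3 (0.13 log units; that floor lies within the scatter), which lies within the scatter.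

Compound 4, `COc1cc(Nc2nc(SCc3ccc(C(F)(F)F)cc3)nc3ccccc23)cc(OC)c1`, has not yet been measured. The change from compound 3 is 3,5-dimethoxyphenyl in place of 4-ethoxyphenyl on a nitrogen on an aromatic ring. Going by the values given here, two measured steps bear on this ring. The step of an at least 1.3-fold lower number from compound 1 to compound 3 (0.13 log units; that floor lies within the scatter) moved a single ethoxy group within the ring and showed no sizeable effect. The step of a 6.0-fold higher number from compound 2 to compound 3 (0.78 log units; beyond the scatter) replaced trifluoromethyl by ethoxy and raised the number modestly. Compound 3 with an ethoxy group on this ring gives 37000 nM, and compound 4 keeps alkoxy groups there. The expected step of a 1.1-fold lower number from compound 3 to compound 4 (0.02 log units; within the scatter) is therefore none beyond the scatter. The estimate for compound 4 in this assay is 35000 nM, with a range from 12000 nM to 90000 nM.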

Compound 4, half-maximal inhibitory concentration: 8580 nM
Beside the measured number, compound 4's estimate is 4.1-fold (0.61 log units) above it; measured number outside the range, below it.
By their numbers in this assay, from the lowest: compounds 2 and 4 (each within the scatter of the next); then compound 3. At a limit, above all of these: compound 1.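

Until now, alkoxy groups on this ring had come only with the higher numbers, but 3,5-dimethoxyphenyl in place of 4-ethoxyphenyl gives a 4.3-fold lower number from compound 3 to compound 4 (0.63 log units; beyond the scatter), so an alkoxy group on this ring does not by itself bring a high number. The exchange of 3,5-dimethoxyphenyl for 4-(trifluoromethyl)phenyl gives a 1.4-fold higher number from compound 2 to compound 4 (0.14 log units; within the scatter), which means that this assay does not tell these two rings apart, even though they carry very different groups. The remaining step, an at least 5.8-fold lower number from compound 1 to compound 4 (0.76 log units; beyond the scatter), is only a floor, set by compound 1, which stands at a limit of the assay rather than at a number: the limit of > 50000 nM in this assay, at which 1 of the 4 values shown sits.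

The change from 4-ethoxyphenyl to 3,5-dimethoxyphenyl alters the kind of alkoxy group, how many there are and where they sit all at once, so the compounds shown cannot say which of these matters. Going by these compounds, it also remains open how this ring would fare with an amine or a carboxylic acid on it, or with a longer chain such as butoxy in place of the methoxy groups.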